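A few compounds are considered here, and "the series" means these few. Any claim that something is new, unique, unknown or untested is made for them only; others in the source may bear on it.

Measured compounds:
compound 1 `COc1ccc(N(C)c2nc(C)nc3ccccc23)cc1OCCN` — 682 nM
compound 2 `COc1ccc(N(C)c2nc(C)nc3ccccc23)cc1C(=O)OCCCCC[Se]C#N` — 851 nM
compound 3 `C[Se]c1ccc(N(C)c2nc(C3CC3)nc3ccccc23)cc1` — 18 nM

In a functional assay on MDA-MB-231 cells (Homo sapiens) for inhibition, read by MTT assay, with a stated time of 48 h (a lower number here means a stronger inhibitor, a higher number a weaker inhibitor), compound 1 gives 682 nM, the second highest of the three numbers. Its nearest neighbour is compound 2 at 851 nM, a gap that lies within the scatter, so no order between compound 1 and compound 2 can be read. Compound 3 gives 18 nM, a much lower number than compound 1, and that gap lies beyond the scatter.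

Compound 4 `COc1ccc(N(C)c2nc(C)nc3ccccc23)cc1OCCCCC[Se]C#N` is not yet measured. It differs from compound 1 in one place: a group of 6 heavy atoms (4 carbon, 1 nitrogen, 1 selenium; no ring) in place of one nitrogen atom, on a saturated chain carbon, two bonds along the chain from an oxygen on an aromatic ring

Among the measured compounds shown here, no step between measured compounds is available for this kind of change. Compound 2, which also carries a chain ending in the same selenium-bearing group, gives a number that sits within the scatter of compound 1, so the change is expected to move this assay little, if at all, beyond the scatter, with no clear direction. The estimate for compound 4 in this assay is 600 nM, with a range from 250 nM to 1500 nM. That expected step is a 1.1-fold lower number from compound 1 to compound 4 (0.06 log units; within the scatter).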

Compound 4, half-maximal inhibitory concentration: 4410 nM
Compound 4: middle estimate off by 7.4-fold (0.87 log units), on the low side; the whole stated range lies below it.
By their numbers in this assay, from the lowest: compound 3; then compounds 1 and 2 (each within the scatter of the next); then compound 4.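

In this assay, putting the selenium-bearing group in place of amino, on a saturated chain carbon two bonds along the chain from an oxygen on an aromatic ring, is not a neutral change: it gives a 6.5-fold higher number from compound 1 to compound 4 (0.81 log units; beyond the scatter). The selenium-bearing chain end alone does not set the number, since a carbonyl that compound 4 lacks is carried by compound 2, which gives 851 nM, while compound 4 gives 4410 nM. Nothing available bears on the reason for this step.

Still open, from the compounds shown here alone, is whether the step follows the longer chain or its selenium-bearing end. A longer chain ending in an amine, or one ending in a nitrile without selenium, would separate the two.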